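The source may hold more compounds than are shown below. What is called first, only, known or untested is meant among the compounds shown, and "the series" means these compounds.

Among the measured compounds shown here, compound 1 `COc1ccc(OC)c(/C=N/NC(=O)Nc2ccc(Oc3ccnc(-c4nncn4CCN(C)C)c3)c(F)c2)c1` stands lowest of the three numbers so far in a functional assay on A549 cells (Homo sapiens) for cytotoxicity, read by MTT assay, with a stated time of 72 h; on this read-out lower numbers stand for stronger inhibition and higher numbers for weaker inhibition; in this assay compound 1 gives 1950 nM. Compound 3 `CN(C)CCn1cnnc1-c1cc(Oc2ccc(NC(=O)N/N=C/c3ccc(O)cc3)cc2F)ccn1` gives 3560 nM, a step of a 1.8-fold higher number from compound 1 to compound 3 (0.26 log units; within the scatter). Compound 2 `CN(C)CCn1cnnc1-c1cc(Oc2ccc(NC(=O)N/N=C/c3ccc(O)c(F)c3)cc2F)ccn1` gives 13400 nM, a step of a 6.9-fold higher number from compound 1 to compound 2 (0.84 log units; beyond the scatter), and from compound 2 to compound 3 the step is a 3.8-fold lower number from compound 2 to compound 3 (0.58 log units; beyond the scatter). Compound 4 `CN(C)CCn1cnnc1-c1cc(Oc2ccc(NC(=O)N/N=C/c3ccc(O)c(Br)c3)cc2F)ccn1` differs from compound 1 in one place: 3-bromo-4-hydroxyphenyl in place of 2,5-dimethoxyphenyl on a carbon with a double bond to nitrogen. The steps to compound 2 and compound 3 bear on this change, since both carry a hydroxyphenyl on the same carbon, one with a fluoro beside the hydroxyl and one without. A modest rise in the number is therefore expected, a 4.1-fold higher number from compound 1 to compound 4 (0.61 log units; beyond the scatter), and compound 4 is estimated at 8000 nM, within a range of 3000 nM to 22000 nM.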

Compound 4, half-maximal inhibitory concentration: 1370 nM
Beside the measured number, compound 4's estimate is 5.8-fold (0.77 log units) above it; the measured number lies below the stated range.
By their numbers in this assay, from the lowest: compounds 4, 1 and 3 (each within the scatter of the next, the first and the last beyond it); then compound 2.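

In this assay the group on the hydroxyphenyl ring matters, and its direction depends on the group: bromo in place of hydrogen gives a 2.6-fold lower number from compound 3 to compound 4 (0.41 log units; beyond the scatter), whereas bromo in place of fluoro gives a 9.8-fold lower number from compound 2 to compound 4 (0.99 log units; beyond the scatter). The 3-bromo-4-hydroxyphenyl group also keeps pace with 2,5-dimethoxyphenyl, with a 1.4-fold lower number from compound 1 to compound 4 (0.15 log units; within the scatter). No evidence here accounts for the opposite results of bromo and fluoro. The compounds shown leave open whether chloro or methyl in the place of bromo would follow bromo or fluoro, and whether an amine could replace the hydroxyl.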